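The source may hold more compounds than are shown below. What is called first, only, known or untested is meant among the compounds shown, and "the series" means these compounds.

Compounds measured so far:
compound 1, `COc1cc(C(C)=O)ccc1OCCCN1CCC(C(c2ccccc2)c2ccccc2)CC1`, 6.31 nM
compound 2, `N#Cc1ccc(OCCCN2CCC(C(c3ccc(F)cc3)c3ccc(F)cc3)CC2)cc1`, 5.01 nM

In a functional assay (aorta) with Oryctolagus cuniculus as the target (on this read-out higher numbers stand for weaker binding and lower numbers for tighter binding), compound 2 gives 5.01 nM, and compound 1 gives 6.31 nM; the two numbers lie within the scatter of each other, so neither compound stands apart. Compound 3, `Fc1ccc(C(c2ccc(F)cc2)C2CCN(CCCCc3ccccc3)CC2)cc1`, is not yet measured. It differs from compound 2 in one place: benzyl in place of 4-cyanophenoxy on a saturated chain carbon, three bonds along the chain from an amine nitrogen in a ring. No step between measured compounds is available, so the effect of this change has no precedent among these compounds. Compound 3 is expected to give a somewhat higher number, estimated at 20 nM with a range from 5 nM to 80 nM. The expected step is a 4.0-fold higher number from compound 2 to compound 3 (0.60 log units; beyond the scatter).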

Compound 3, dissociation constant: 2.51 nM
For compound 3 the middle estimate is 8.0-fold (0.90 log units) above the measured one; measured number below the stated range.
By their numbers in this assay, from the lowest: compounds 3, 2 and 1 (each within the scatter of the next, the first and the last beyond it).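

In this assay, benzyl in place of 4-cyanophenoxy gives a 2.0-fold lower number from compound 2 to compound 3 (0.30 log units; within the scatter). At this position, then, the group can lose its nitrile, its oxygen and both hydrogen-bond acceptors without the number moving beyond the usual scatter. Nothing available explains this result. From the compounds shown here alone, it remains open whether an amine, a carboxylic acid or a longer chain in place of benzyl would also stay within the scatter. Also open, going by these compounds, is whether the same exchange would give a similar step on the core of compound 1.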